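A few compounds are considered here, and "the series" means these few. Any claim that something is new, unique, unknown or untested is made for them only; others in the source may bear on it.

Compound 1 `COc1cc(/C=C2\SC(=O)NC2=O)ccc1OCN1C(=O)c2ccccc2C1=O` gives 35100 nM in an assay on isolated protein for inhibition of Alpha glucosidase (Homo sapiens), read by spectrophotometry, with stated times of 15 min and 30 min; on this read-out higher numbers stand for weaker inhibition and lower numbers for stronger inhibition. Compound 2 `CCOc1cc(/C=C2\SC(=O)NC2=O)ccc1OCN1C(=O)c2ccccc2C1=O` gives 29300 nM, and compound 3 `COc1cc(/C=C2\SC(=S)NC2=O)ccc1OCN1C(=O)c2ccccc2C1=O` gives 16100 nM. Compound 3 stands apart from compound 1, since a 2.2-fold lower number from compound 1 to compound 3 (0.34 log units; beyond the scatter), whereas compound 3 and compound 2 lie within the scatter of each other. Compound 4 `CCOc1cc(/C=C2\SC(=S)NC2=O)ccc1OCN1C(=O)c2ccccc2C1=O` differs from compound 3 by methyl in place of hydrogen on a saturated chain carbon bound to an oxygen on an aromatic ring. The same change has been measured once already, and a 1.2-fold lower number from compound 1 to compound 2 (0.08 log units; within the scatter). That step therefore suggests no shift beyond the scatter in this assay when the change is made on compound 3. Compound 4 is thus expected to give about 13000 nM, within a range of 6500 nM to 26000 nM. This estimate means a 1.2-fold lower number from compound 3 to compound 4 (0.09 log units; within the scatter), a step expected to stay within the scatter.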

Compound 4, half-maximal inhibitory concentration: 7720 nM
For compound 4 the middle estimate is 1.7-fold (0.23 log units) above the measured one; measured number inside the range.
By their numbers in this assay, from the lowest: compound 4; then compounds 3, 2 and 1 (each within the scatter of the next, the first and the last beyond it).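

In this assay, the change from methoxy to ethoxy now gives a 2.1-fold lower number from compound 3 to compound 4 (0.32 log units; beyond the scatter), a step beyond the scatter that the earlier pair did not show, yet the two steps cannot be told apart: the same change on two cores in this assay, a 1.2-fold lower number (0.08 log units; within the scatter) from compound 1 to compound 2 and a 2.1-fold lower number (0.32 log units; beyond the scatter) from compound 3 to compound 4, 1.7-fold (0.24 log units) apart, within the scatter of two such steps. Exchanging one oxygen for sulfur in the five-membered ring also carries over to the ethoxy compounds, giving a 3.8-fold lower number from compound 2 to compound 4 (0.58 log units; beyond the scatter), and its size holds as well: the same change on two cores in this assay, a 2.2-fold lower number (0.34 log units; beyond the scatter) from compound 1 to compound 3 and a 3.8-fold lower number (0.58 log units; beyond the scatter) from compound 2 to compound 4, 1.7-fold (0.24 log units) apart, within the scatter of two such steps. Compound 4 therefore combines both changes, and its number is the lowest of the four, clearly so only against compounds 1 and 2 by their steps. On these data alone, whether a longer chain such as propoxy, or an amine in place of the methyl, would lower the number further remains open.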